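Swapping Bromine for Chlorine in a Sulfonamide Series

The source may hold more compounds than are shown below. What is called first, only, known or untested is meant among the compounds shown, and "the series" means these compounds.

Measured compounds:
- compound 1, `CCOC(=O)c1oc2ccc(NS(=O)(=O)c3ccc(Br)cc3)cc2c1C`: > 40000 nM
- compound 2, `CCOC(=O)c1oc2ccc(NS(=O)(=O)c3ccc(Cl)cc3)cc2c1C`: > 40000 nM
- compound 3, `Cc1c(C(=O)O)oc2ccc(N(Cc3ccccc3)S(=O)(=O)c3ccc(Br)cc3)cc12`: 20000 nM

In a functional assay on HCT-116 cells (Homo sapiens) for inhibition, read by MTT assay, with a stated time of 72 h (a higher number here means a weaker inhibitor, a lower number a stronger inhibitor), compound 1 reaches only a limit of the assay, > 40000 nM. Compound 2 likewise gives only a limit, > 40000 nM. Compound 3, by contrast, gives a number in this assay, 20000 nM. The difference between the core of compound 1 and the core of compound 3 is not broken down here.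

From compound 1 to compound 2 the change is chloro in place of bromo on an aromatic carbon. The resulting step, a step that the two limits leave unreadable from compound 1 to compound 2, cannot be sized, since (the limit of > 40000 nM in this assay, at which 2 of the 3 values shown sit).

Compound 4, `Cc1c(C(=O)O)oc2ccc(N(Cc3ccccc3)S(=O)(=O)c3ccc(Cl)cc3)cc12`, is not yet measured. From compound 3 to compound 4 the change is chloro in place of bromo on an aromatic carbon, the same change as from compound 1 to compound 2. Because the measured pair leaves the step unreadable, given (the limit of > 40000 nM in this assay, at which 2 of the 3 values shown sit), the expectation for compound 4 rests mainly on compound 3 and its value 20000 nM. The step of a 1.3-fold higher number from compound 3 to compound 4 (0.10 log units; within the scatter) is expected to stay small. Compound 4 is therefore estimated at 25000 nM, likely between 10000 nM and 60000 nM.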

Compound 4, half-maximal inhibitory concentration: 33400 nM
Beside the measured number, compound 4's estimate is 1.3-fold (0.13 log units) below it; low and high end bracket the measured number.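

In this assay, chloro in place of bromo on the core of compound 3 gives a 1.7-fold higher number from compound 3 to compound 4 (0.22 log units; within the scatter), so on this core the two halogens cannot be told apart. The same swap on the core of compound 1 cannot be read, since compound 1 and compound 2 each give only a limit of the assay, not a number: the limit of > 40000 nM in this assay, at which 2 of the 4 values shown sit. The series therefore offers one readable pair on one core, which shows that the swap is tolerated there but does not show that it would carry over to another core with an equally small step.

The compounds shown also leave open what a group other than these two halogens would do at the same place on the ring, such as a nitrile, a methoxy or an amine. Within the data shown here, no pair here differs only in the ethyl ester versus the carboxylic acid, or only in the benzyl group on the sulfonamide nitrogen, so the share of each in the difference between the two cores stays unknown.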